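Working notes on cytotoxicity for compounds 1 to 4

The compounds below may be only part of what the source reports. "The series", "measured", "known", "first", "only" and "open" are said of these compounds alone.

Compound 1 `O=C(O)c1cccn1-c1ccc2c(c1)B(O)OC2` is the acid of the shared core. In an ADME assay on L929 cells (Mus musculus) for cytotoxicity, read by resazurin assay, with a stated time of 72 h (on this read-out lower numbers stand for stronger inhibition and higher numbers for weaker inhibition), compound 1 gives only a limit, > 10 ug/mL. Compound 2 `O=C(NCc1ccccc1)c1cccn1-c1ccc2c(c1)B(O)OC2` carries benzylamino in place of hydroxy on a carbonyl carbon; in this assay compound 2 likewise reaches only the limit > 10 ug/mL. The step that the two limits leave unreadable from compound 1 to compound 2 is accordingly not readable. Compound 3 `O=C(c1ccn(-c2ccc3c(c2)B(O)OC3)c1)c1ccccc1Cl` also stops at the limit in this assay, with > 10 ug/mL. The whole of the evidence so far is the limit of > 10 ug/mL in this assay, at which 3 of the 3 values shown sit, so compound 3 cannot be placed on a number relative to either other compound.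

Compound 4 `CCCC(=O)c1ccn(-c2ccc3c(c2)B(O)OC3)c1` differs from compound 3 as follows: propyl in place of 2-chlorophenyl on a carbonyl carbon. Among the measured compounds shown here, no measured step concerns a change on this carbonyl carbon, and the single measured step, a step that the two limits leave unreadable from compound 1 to compound 2, gives no size. Nothing in the series shows cytotoxicity appearing within the measured range, so no step beyond the scatter is expected in this assay. Compound 4 is therefore expected to give about 15 ug/mL, in the range 8 ug/mL to 40 ug/mL, most probably reported again as a limit. The expected step that the limit leaves unreadable from compound 3 to compound 4 is judged to lie within the scatter.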

Compound 4, half-maximal inhibitory concentration: > 10 ug/mL
Compound 4: no number, only a limit; the forecaster's own chance of this, stated with the estimate: 85%; the middle value is on the limit's open side.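

Compound 3 and compound 4 both stop at a limit, so no step can be read between them. The compounds shown leave open at what concentration any of them becomes cytotoxic in this assay, and whether any change shown alters that: the limit of > 10 ug/mL in this assay, at which 4 of the 4 values shown sit.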